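Methoxy for chloro on compound 3: expected cytotoxicity

The source may report more compounds than this note shows. Statements on the series, on what has been measured and on what is new or still open speak of the compounds shown alone.

Compound 3 `Cc1c(C(=O)N=[N+]=[N-])[n+]([O-])c2cc(Cl)ccc2[n+]1[O-]` gives 70.3% in a functional assay on Ehrlich cells (Mus musculus) for cytotoxicity, read by trypan blue exclusion, with a stated time of 2 h, tested at 50 ug/mL (a lower number here means a stronger effect, a higher number a weaker effect of the compound at the concentration tested), the second highest of the three numbers; compound 1 `CNc1c(C#N)[n+]([O-])c2cc(Cl)ccc2[n+]1[O-]` gives 81.4%, and compound 2 `CC(=O)N(C(C)=O)c1c(C#N)[n+]([O-])c2cc(Cl)ccc2[n+]1[O-]` gives 1.3%, the furthest from compound 3. For the measured compounds named here, the only single-point step measured is a number 80.1 percentage points lower from compound 1 to compound 2 (beyond the scatter), a change at a different aromatic carbon of the shared core from the one in question here. Compound 4 `COc1ccc2c(c1)[n+]([O-])c(C(=O)N=[N+]=[N-])c(C)[n+]2[O-]` differs from compound 3 by methoxy in place of chloro on an aromatic carbon. Going by the values given here, no measured step bears on this exchange, so no change beyond the scatter is expected, and the step is estimated as a number 0.3 percentage points lower from compound 3 to compound 4 (within the scatter). For compound 4 the estimate in this assay is 70%, expected to lie between 45% and 90%.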

Compound 4, a percentage reported as activity, at one concentration (the size of the read-out at that concentration, not a potency): 6.2%
Compound 4: the middle estimate sits 63.8 percentage points above what was measured, and the stated range ends above it.
By their numbers in this assay, from the lowest: compounds 2 and 4 (each within the scatter of the next); then compound 3; then compound 1.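

In this assay, the exchange of chloro for methoxy gives a number 64.1 percentage points lower from compound 3 to compound 4 (beyond the scatter), so this aromatic carbon is not a silent place in the series. The earlier large step lay at a different aromatic carbon of the shared core; this one shows that the read-out also responds to a single exchange here. No measurement at hand accounts for this drop.

Open, as far as these compounds go, is whether ethoxy, a longer alkoxy chain or an amine on this carbon stays with compound 4 or returns towards compound 3. Also open, from the compounds shown here alone, is whether methoxy for chloro acts the same way on compound 1.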